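The source may hold more compounds than are shown below. What is called first, only, known or untested is meant among the compounds shown, and "the series" means these compounds.

In a functional assay on isolated protein for inhibition of Glucose-dependent insulinotropic receptor (Rattus norvegicus), read by HTRF and cAMP accumulation (on this read-out lower numbers stand for smaller maximal responses and higher numbers for larger maximal responses), compound 1 `Cc1nc(S(C)(=O)=O)ccc1Oc1ncnc(OC2CCN(C(=O)O[C@@H](C)C(F)(F)F)CC2)c1F` gives 80%. Within the data shown here, it is one of only two compounds measured, and the other, compound 2 `Cc1nc(S(C)(=O)=O)ccc1Oc1ncnc(OC2CCN(C(=O)SC3(C)CC3)CC2)c1F`, gives 77% in this assay. The step of a number 3 percentage points lower from compound 1 to compound 2 (within the scatter) lies within the scatter, so compound 1 holds the upper of the two numbers without being separated from its neighbour.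

Compound 3 `Cc1nc(S(C)(=O)=O)ccc1Oc1ncnc(OC2CCN(C(=O)C(C)(C)F)CC2)c1F` has not yet been measured. It differs from compound 1 in this way: 1-fluoro-1-methylethyl in place of 1-(trifluoromethyl)ethoxy on a carbonyl carbon. Among the measured compounds shown here, only one measured step speaks to this change, the one at the same carbonyl carbon, a number 3 percentage points lower from compound 1 to compound 2 (within the scatter), where a group of five heavy atoms with a three-membered ring replaced the seven-atom group, and the response stayed within the scatter. On that single precedent the exchange of the 1-(trifluoromethyl)ethoxy group for 1-fluoro-1-methylethyl on the carbonyl carbon is expected to leave the maximal response essentially unchanged, with a step of a number 3 percentage points lower from compound 1 to compound 3 (within the scatter) that stays within the scatter. Compound 3 is therefore estimated to give 77% in this assay, within a range from 64% to 90%.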

Compound 3, largest response reached (reported as efficacy), in percent of the reference or control that the assay uses: 74%
Estimate against measurement, compound 3: 3 percentage points above, within the range that was stated.
By their numbers in this assay, from the lowest: compounds 3, 2 and 1 (each within the scatter of the next).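

In this assay the carbonyl carbon on the amide-type nitrogen in a ring has now taken a third group, and the exchange of 1-(trifluoromethyl)ethoxy for 1-fluoro-1-methylethyl gives a number 6 percentage points lower from compound 1 to compound 3 (within the scatter), so a group of fewer heavy atoms, with no hydrogen-bond acceptor and no defined stereocentre, and with carbon rather than oxygen as the atom joined to the carbonyl, is tolerated on this read-out. The comparison with the sulfur-linked methylcyclopropyl group of compound 2 gives a number 3 percentage points lower from compound 2 to compound 3 (within the scatter), which means that neither the ring nor the sulfur of that group is needed to keep the response in this range, and all three compounds now sit within the scatter of one another. No measurement available here accounts for this flat response across the three groups.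

Going by these compounds, what remains open is whether any group on this carbonyl carbon separates from these three at all, for instance an amine, a carboxylic acid or a longer alkyl chain. Since all three compounds share the same core, they also say nothing about changes elsewhere in the molecule, such as replacing the methylsulfonyl group or the ring fluorine.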